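Alkoxy chain length in the benzamido-benzoic acid series

The source may report more compounds than this note shows. Statements on the series, on what has been measured and on what is new or still open speak of the compounds shown alone.

Measured so far:
compound 1, `O=C(O)c1cccc(NC(=O)c2ccc(Oc3ccccc3)cc2)c1`, 97 nM
compound 2, `COc1ccccc1C(=O)Nc1cccc(C(=O)O)c1`, > 10000 nM
compound 3, `CCOc1cccc(C(=O)Nc2cccc(C(=O)O)c2)c1`, 2350 nM

In an assay on isolated protein for agonist activity at Bile acid receptor (Homo sapiens), read by TR-FRET, with a stated time of 3 h, in the absence of a further agent (a higher number here means that more compound is needed for the effect, a lower number that less compound is needed), compound 1 gives 97 nM. Compound 2 reaches only the assay limit, > 10000 nM, so it gives no number (the limit of > 10000 nM in this assay, at which 1 of the 3 values shown sits). Compound 3 gives 2350 nM and so stands highest of the two numbers available; the nearest number is that of compound 1, which sits well beyond the scatter below it. For the measured compounds named here, no pair of measured compounds differs in a single place, so no measured step is available to lean on.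

Compound 4, `CC(C)CCOc1cccc(C(=O)Nc2cccc(C(=O)O)c2)c1`, is not yet measured. Relative to compound 3 the change is isopropyl in place of hydrogen on a saturated chain carbon, two bonds along the chain from an oxygen on an aromatic ring. Among the measured compounds, compound 1 with the larger phenoxy substituent gives the lower number, while compound 3 with ethoxy gives the higher one; this is the only hint on the effect of a larger group at this position and rests on two compounds alone.

On that basis compound 4 is expected to give a lower number than compound 3, a step estimated as a 6.7-fold lower number from compound 3 to compound 4 (0.83 log units; beyond the scatter) in this assay. The estimate for compound 4 in this assay is 350 nM, with a range from 60 nM to 2000 nM.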

Compound 4, half-maximal effective concentration: 2760 nM
The estimate for compound 4 lay 7.9-fold (0.90 log units) below the measured number, and the stated range ends below it.
By their numbers in this assay, from the lowest: compound 1; then compounds 3 and 4 (each within the scatter of the next). At a limit, above all of these: compound 2.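

In this assay, going from ethoxy to isopentyloxy gives a 1.2-fold higher number from compound 3 to compound 4 (0.07 log units; within the scatter) on the shared core, the first step measured at this position. Isopropyl in place of hydrogen on a saturated chain carbon, two bonds along the chain from an oxygen on an aromatic ring, therefore does not separate the two compounds, and this longer, branched chain alone does not bring the number towards that of compound 1. Compound 1 differs from compound 3 in more than one place, so its value says nothing about this chain, and no measurement shown gives a reason for the result.

As far as these compounds go, it remains open whether chains of intermediate length, such as propoxy or butoxy, or an unbranched chain such as n-pentyloxy, would stand with compound 3 and compound 4 or apart from them. Also open, from the compounds shown here alone, is whether a phenyl ring, an amine or a hydroxyl at the end of the chain, as in benzyloxy or 2-aminoethoxy, would move the number beyond the scatter from that of compound 3.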